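The source may report more compounds than this note shows. Statements on the series, on what has been measured and on what is new or still open speak of the compounds shown alone.

Of the compounds shown here, two have been tested in a functional assay on CCRF-CEM cells (Homo sapiens) for cytotoxicity, with a stated time of 72 h; a higher number here means a weaker inhibitor, a lower number a stronger inhibitor. Compound 1 `CN(C)c1ccc(/C=C2\CCC/C(=C\c3cccc([N+](=O)[O-])c3)C2=O)cc1` gives 11700 nM, and compound 2 `O=C1/C(=C/c2ccccc2)CCC/C1=C\c1cccc([N+](=O)[O-])c1` gives 2290 nM; the step of a 5.1-fold lower number from compound 1 to compound 2 (0.71 log units; beyond the scatter) makes compound 2 the lower of the two numbers. Compound 3 `COc1ccc(/C=C2\CCC/C(=C\c3cccc([N+](=O)[O-])c3)C2=O)cc1` differs from compound 2 by methoxy in place of hydrogen on an aromatic carbon. For the measured compounds named here, the only measured step bearing on this is a 5.1-fold lower number from compound 1 to compound 2 (0.71 log units; beyond the scatter), where removing a group from an aromatic carbon lowered the number modestly. Adding methoxy there is therefore expected to raise the number by a 2.2-fold higher number from compound 2 to compound 3 (0.34 log units; beyond the scatter), so compound 3 is estimated at 5000 nM in this assay, within 2000 nM to 12000 nM.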

Compound 3, half-maximal inhibitory concentration in the CCRF-CEM assay: 8220 nM
The estimate for compound 3 lay 1.6-fold (0.22 log units) below the measured number; measured number inside the range.
By their numbers in the CCRF-CEM assay, from the lowest: compound 2; then compounds 3 and 1 (each within the scatter of the next).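

In the CCRF-CEM assay, methoxy in place of hydrogen gives a 3.6-fold higher number from compound 2 to compound 3 (0.56 log units; beyond the scatter), so this aromatic carbon responded to a second group, not only to dimethylamino, while methoxy in place of dimethylamino gives a 1.4-fold lower number from compound 1 to compound 3 (0.15 log units; within the scatter), leaving those two groups level. In a physicochemical assay for lipophilicity (a lower number here means a more polar compound, a higher number a more lipophilic compound), compound 2 gives 5.06 and compound 3 gives 5.06, so the cell result shifted while this partition coefficient stayed the same. Nothing available explains the shift. As far as these compounds go, whether a chlorine atom or a carboxylic acid on this same carbon would fall nearer compound 2 or nearer compound 3 remains open.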